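From a dipropyl arm to a branched diisopropyl arm

The compounds below may be only part of what the source reports. "The series", "measured", "known", "first", "only" and "open" are said of these compounds alone.

Compound 3 `CCCN(CCC)CCN(C(=O)N(C)C)c1cc(C)cc(C)n1` stands highest of the three compounds measured in a functional assay on the whole organism (stomach) for inhibition, with Canis familiaris (Canis lupus familiaris) as the target, at a dose of 40 mg/kg by the oral route; on this read-out lower numbers stand for a weaker effect and higher numbers for a stronger effect at the one dose given: compound 3 gives 93%. Its nearest neighbour is compound 2 `Cc1cc(C)nc(N(CCNC(C)C)C(=O)N(C)C)c1`, which gives 42%, and the furthest is compound 1 `CNCCN(C(=O)N(C)C)c1cc(C)cc(C)n1`, which gives 20%. Both gaps lie beyond the scatter, shown by a number 51 percentage points higher from compound 2 to compound 3 (beyond the scatter) and a number 73 percentage points higher from compound 1 to compound 3 (beyond the scatter).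

Compound 4 `Cc1cc(C)nc(N(CCCN(C(C)C)C(C)C)C(=O)N(C)C)c1` has not been measured. Compared with compound 3 it carries (diisopropylamino)methyl in place of dipropylamino on a saturated chain carbon, two bonds along the chain from an amide-type nitrogen. Two kinds of measured step bear on this change. Putting dipropylamino in place of methylamino or isopropylamino gave a number 73 percentage points higher from compound 1 to compound 3 (beyond the scatter) and a number 51 percentage points higher from compound 2 to compound 3 (beyond the scatter); putting isopropyl in place of methyl on an amine nitrogen gave a number 22 percentage points higher from compound 1 to compound 2 (beyond the scatter). Among the compounds with values here, compound 4 keeps two alkyl groups on the amine nitrogen and adds the branching that helped before, so none of the measured steps points downward, yet compound 3 already sits close to the top of the scale and leaves little room for a further rise. The step to compound 4 is therefore expected to be small, a number 13 percentage points lower from compound 3 to compound 4 (beyond the scatter), within or near the scatter. Compound 4 is estimated to give 80%, in a range from 55% to 98%.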

Compound 4, a percentage reported as inhibition, in the whole organism at one dose (the size of the read-out at that dose, not a potency): 35%
Compound 4: middle estimate off by 45 percentage points, on the high side; measured number outside the range, below it.
By their numbers in this assay, from the lowest: compound 1; then compounds 4 and 2 (each within the scatter of the next); then compound 3.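

In this assay, the dipropylamino arm proves not to be replaceable by just any arm that keeps two alkyl groups on the amine nitrogen: exchanging it for (diisopropylamino)methyl at this place on the saturated chain costs most of the effect (a number 58 percentage points lower from compound 3 to compound 4 (beyond the scatter)). The branching that went with a rise on the amine nitrogen earlier does not carry over to this change, and compound 4 cannot be told apart from the singly substituted isopropyl compound (a number 7 percentage points lower from compound 2 to compound 4 (within the scatter)), while it retains only a modest edge over the methylamino compound (a number 15 percentage points higher from compound 1 to compound 4 (beyond the scatter)). So, at this position, the amine groups do not rank by size or by the number of alkyl groups alone, and nothing measured on the compounds here accounts for the drop.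

The change alters the alkyl groups on the amine and adds a methyl link in one step, so the compounds shown leave open which of the two goes with the loss. A (dipropylamino)methyl arm or a diisopropylamino arm would each vary one of these alone.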